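This account rests on a few compounds, and the source may have more. Where it says the series, first, only, none or still open, it means among the compounds named here.

In a functional assay on the whole organism with Rattus norvegicus as the target (a higher number here means that more compound is needed for the effect, a lower number that less compound is needed), two compounds on a shared core have been measured so far. Compound 1 `CCOCCOC(=O)C(=O)Nc1nc(-c2cc(Cl)no2)cs1` gives 6 mg/kg. Compound 2 `O=C(O)C(=O)Nc1nc(-c2cc(Cl)no2)cs1` is recorded at > 30 mg/kg, which is a limit of the assay and not a number. Its standing is therefore (the limit of > 30 mg/kg in this assay, at which 1 of the 2 values shown sits), with no exact position.

For the measured compounds named here, the one measured step, an at least 5.0-fold higher number from compound 1 to compound 2 (0.69 log units; beyond the scatter), exchanges 2-ethoxyethyl for hydrogen on an oxygen next to a carbonyl group. It lies beyond the scatter but sits at a different place from the change now in question, so it bears on that change only indirectly.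

Compound 3 `O=C(O)C(=O)Nc1nc(-c2cc(-c3c(F)cccc3Cl)no2)cs1` keeps that hydrogen and carries 2-chloro-6-fluorophenyl in place of chloro on an aromatic carbon. Going by the values given here, no measured step covers this place, so any size remains poorly constrained. A modest move to a lower number in this assay is expected, and a second result at a limit remains possible. The expected step is an at least 2.0-fold lower number from compound 2 to compound 3 (0.30 log units; that floor lies within the scatter). For compound 3 the estimated value is 15 mg/kg, with an expected range of 3 mg/kg to 40 mg/kg.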

Compound 3, dose for half-maximal effect: 2.4 mg/kg
The estimate for compound 3 lay 6.3-fold (0.80 log units) above the measured number; the measured number lies below the stated range.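

In this assay, the aromatic carbon next to the ring nitrogen turns out to be a place that responds strongly: 2-chloro-6-fluorophenyl in place of chloro gives an at least 12-fold lower number from compound 2 to compound 3 (1.09 log units; beyond the scatter). Hydrogen on the oxygen next to a carbonyl group does not by itself prevent an exact reading in the series, since compound 3 carries that hydrogen and gives 2.4 mg/kg. The size of the step remains a floor and not an exact figure, because compound 2 is recorded only at a limit of the assay: the limit of > 30 mg/kg in this assay, at which 1 of the 3 values shown sits.

The compounds shown do not separate what the phenyl ring contributes from what its chlorine and fluorine contribute, so plain phenyl, or a smaller group such as methyl or an amine on the same carbon, would be needed to tell how much of the step belongs to each part. Also open, from the compounds shown here alone, is whether 2-ethoxyethyl on the oxygen next to the carbonyl group, combined with 2-chloro-6-fluorophenyl, would lower the number further, as the two changes have so far been read only apart from each other.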